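Taking the propyl group off compound 3

The source may report more compounds than this note shows. Statements on the series, on what has been measured and on what is new or still open speak of the compounds shown alone.

In a functional assay (plasma) with Oryctolagus cuniculus as the target (on this read-out higher numbers stand for weaker inhibition and lower numbers for stronger inhibition), three compounds have numbers so far:

Compound 1 `COC(=O)NC(CC(=O)N1CCC(Cn2c(C)nc3cnccc32)CC1)c1ccccc1` gives 12 nM
Compound 2 `COC(=O)NC(CC(=O)N1CCC(n2c(C)nc3cnccc32)CC1)c1ccccc1` gives 1300 nM
Compound 3 `CCCC(CC(=O)N1CCC(Cn2c(C)nc3cnccc32)CC1)c1ccccc1` gives 11 nM

Compound 3 sits at the low end of these numbers, level with compound 1 within the scatter, while compound 2 stands well apart on the high side.

The next compound, compound 4 `Cc1nc2cnccc2n1CC1CCN(C(=O)CCc2ccccc2)CC1`, has not yet been measured. It carries hydrogen in place of propyl on a saturated chain carbon bound to an aromatic carbon and a saturated chain carbon, a difference that counts as hydrogen in place of propyl on a saturated chain carbon bound to an aromatic carbon and a saturated chain carbon in full.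

Among the compounds with values here, only one measured step bears on that carbon, namely a 1.1-fold lower number from compound 1 to compound 3 (0.04 log units; within the scatter), with propyl in place of (methoxycarbonyl)amino. That step shows two different groups at this place giving matching numbers. Within the data shown here, it does not show what happens with hydrogen there, since no measured compound has it. The data therefore give only a weak guide, and a moderate move toward a higher number is expected rather than a collapse on the scale of compound 2.

The expected change is a 4.5-fold higher number from compound 3 to compound 4 (0.66 log units; beyond the scatter) in this assay, held with little confidence. Compound 4 is estimated at 50 nM, with an expected range from 12 nM to 250 nM when it is measured.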

Compound 4, half-maximal inhibitory concentration: 60 nM
Compound 4: the middle estimate sits 1.2-fold (0.08 log units) below what was measured; measured number inside the range.
By their numbers in this assay, from the lowest: compounds 3 and 1 (each within the scatter of the next); then compound 4; then compound 2.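

In this assay, within the data shown here, the hydrogen compound gives the first direct reading of this saturated chain carbon without a larger group on it, and the loss of propyl appears as a 5.5-fold higher number from compound 3 to compound 4 (0.74 log units; beyond the scatter) while the loss of (methoxycarbonyl)amino appears as a 5.0-fold higher number from compound 1 to compound 4 (0.70 log units; beyond the scatter) and so the two routes to hydrogen are of similar size. Compounds 1 and 3 had shown only that these two groups match each other, whereas these steps show that each of them gives a lower number than hydrogen, and that the position is therefore not indifferent to what it carries. Nothing in the data gives a measured reason for this difference, so the steps stand without an explanation.

The compounds shown leave open whether a small group such as methyl would already give the lower number of compound 3 or whether something of the size of propyl is needed, and whether a longer chain, a hydroxyl or an amine on this carbon would match it. They also leave open whether hydrogen in place of (methoxycarbonyl)amino would give a step of similar size on the core of compound 2.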